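Swapping Chloro for Methyl on a Sugar-Derived Inhibitor

A few compounds are considered here, and "the series" means these few. Any claim that something is new, unique, unknown or untested is made for them only; others in the source may bear on it.

Of the compounds shown here, three sharing a sugar-derived core have been tested in an assay on isolated protein (Homo sapiens) for inhibition of HEXA/HEXB (Bos taurus), using a Dixon plot; on this read-out higher numbers stand for weaker inhibition and lower numbers for stronger inhibition. Compound 1 `CC(=O)N[C@H]1/C(=N/NC(=O)Nc2ccc3ccccc3c2)O[C@H](CO)[C@@H](O)[C@@H]1O` gives 47 nM. Compound 2 `CC(=O)N[C@H]1/C(=N/NC(=O)Nc2ccc(Cl)cc2)O[C@H](CO)[C@@H](O)[C@@H]1O`, which carries a 4-chlorophenyl group on its urea, gives 170 nM. Compound 3 `CC(=O)N[C@H]1/C(=N/NC(=O)Nc2cccc3ccccc23)O[C@H](CO)[C@@H](O)[C@@H]1O` gives 154 nM. The numbers for compound 2 and compound 3 lie within the usual scatter of each other, so they cannot be told apart; compound 1 stands apart from compound 2, its number lower by a gap beyond the scatter.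

Compound 4 `CC(=O)N[C@H]1/C(=N/NC(=O)Nc2ccc(C)cc2)O[C@H](CO)[C@@H](O)[C@@H]1O` differs from compound 2 in a single place: methyl in place of chloro on an aromatic carbon. For the measured compounds named here, the swap keeps the count of heavy atoms, hydrogen-bond donors and acceptors unchanged, and nothing among the measured compounds speaks to this particular exchange. The step from compound 2 to compound 4 is therefore expected to be small, most likely no change beyond the scatter, with a slight lean toward a higher number, a 1.3-fold higher number from compound 2 to compound 4 (0.11 log units; within the scatter). Compound 4 is expected to give about 220 nM, with a plausible range from 90 nM to 550 nM.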

Compound 4, inhibition constant: 332 nM
Compound 4: middle estimate off by 1.5-fold (0.18 log units), on the low side, within the range that was stated.
By their numbers in this assay, from the lowest: compound 1; then compounds 3, 2 and 4 (each within the scatter of the next, the first and the last beyond it).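

In this assay, for the compounds shown here, methyl in place of chloro on an aromatic carbon, para to a large group, gives a 2.0-fold higher number from compound 2 to compound 4 (0.29 log units; within the scatter) and provides the first direct reading at this position. The earlier compounds shown here offered no comparison in which only one place differs, whereas this pair shows that compound 2 and compound 4 cannot be told apart despite the exchange of chloro for methyl. No other data shown bear on the reason for this result.

On these data alone, what remains open is how the same position responds to groups unlike these two, such as an amine, a carboxylic acid or a methoxy group. Also open, as far as these compounds go, is whether a plain hydrogen on that aromatic carbon, with neither chloro nor methyl, would stand beyond the scatter from compound 2.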